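The compounds below may be only part of what the source reports. "The series", "measured", "known", "first", "only" and "open" are said of these compounds alone.

Compound 1 `Cc1nc(SCC(=O)Nc2nc(-c3ccc(Cl)cc3)cs2)n(Nc2ccccc2)c1C` is the anchor of this small set. In a functional assay on OVCAR-3 cells (Homo sapiens) for antiproliferative activity, read by sulforhodamine B assay, with a stated time of 48 h (a lower number here means that less compound is tolerated, a higher number that more compound is tolerated), compound 1 gives 36200 nM. Among the results shown in this assay, that is the only true number; the one other result is a limit rather than a number. Compound 2 `Cc1ccc(Nn2c(SCC(=O)Nc3nc(-c4ccccc4)cs3)nc(C)c2C)cc1` differs from compound 1 at more than one place and sits at the limit of > 100000 nM in this assay, at which 1 of the 2 values shown sits, in this assay. Compound 2 thus gives > 100000 nM, which is a limit and not a measured number. Compound 3 `COc1ccc(Nn2c(SCC(=O)Nc3nc(-c4ccc(Cl)cc4)cs3)nc(C)c2C)cc1` has not yet been measured in this assay. It differs from compound 1 by methoxy in place of hydrogen on an aromatic carbon; read one bond further out, anilino becomes (4-methoxyphenyl)amino. Among the measured compounds shown here, no measured pair in this set differs in a single place, so no step size can be read off directly. A change of this kind is expected to shift the value only modestly, and the expected step is a 1.2-fold higher number from compound 1 to compound 3 (0.09 log units; within the scatter), leaning toward less compound tolerated. Compound 3 is therefore estimated at 45000 nM, with a range from 15000 nM to 150000 nM.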

Compound 3, concentration lethal to 50% of the cells: > 100000 nM
Compound 3: only a limit was reported; the forecaster's own chance of this, stated with the estimate: 30%; middle value at least 2.2-fold (0.34 log units) from the limit.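

Turning anilino into (4-methoxyphenyl)amino gives the first comparison in this set that differs in a single place: in this assay the change is an at least 2.7-fold higher number from compound 1 to compound 3 (0.44 log units; beyond the scatter). This shows that the position is not indifferent to the change, as methoxy here moves the number beyond the scatter, toward more compound tolerated, although only the minimum size of the step can be read. The result for compound 3 is a limit and not a number, and it is the same limit reached by compound 2: the limit of > 100000 nM in this assay, at which 2 of the 3 values shown sit.

Going by these compounds, it remains open whether fluorine, a hydroxy group or an amine at this position would raise the number as well, or whether the shift is particular to methoxy. On these data alone, how far compound 3 lies beyond its limit also remains open.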